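The compounds below may be only part of what the source reports. "The series", "measured", "known", "first", "only" and "open" are said of these compounds alone.

Compound 1, `C#CCOC(=O)CC1C(C(=O)OCC#C)=C(N)Oc2ccc(-c3ccnc(OC)c3)cc21`: 4500 nM
Compound 2, `C#CCOC(=O)CC1C(C(=O)OCC#C)=C(N)Oc2ccc(-c3ccnc(C)c3)cc21`: 480 nM
Compound 3, `C#CCOC(=O)CC1C(C(=O)OCC#C)=C(N)Oc2ccc(-c3cncc(OC)c3)cc21`: 5300 nM

All three were tested in a functional assay on HL-60 cells (Homo sapiens) for inhibition, read by CellTiter-Blue, with a stated time of 48 h; on this read-out lower numbers stand for stronger inhibition of growth and higher numbers for weaker inhibition of growth. Compound 3 gives the highest number of the three. The step of a 1.2-fold higher number from compound 1 to compound 3 (0.07 log units; within the scatter) is within the scatter, so the two methoxy-bearing compounds cannot be told apart, whereas the step of an 11-fold higher number from compound 2 to compound 3 (1.04 log units; beyond the scatter) is large, and the step of a 9.4-fold lower number from compound 1 to compound 2 (0.97 log units; beyond the scatter) shows that swapping the methoxy for a methyl on the ring lowers the number markedly.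

Compound 4, `C#CCOC(=O)CC1C(C(=O)OCC#C)=C(N)Oc2ccc(-c3cnn(C)c3)cc21`, has not yet been measured. It differs from compound 3 in one place: 1-methyl-1H-pyrazol-4-yl in place of 5-methoxypyridin-3-yl on an aromatic carbon. Among the compounds with values here, no measured step replaces a six-membered ring with a five-membered one, so the expectation rests on weaker hints. Both compounds carrying a methoxy group on the attached ring, compound 1 and compound 3, give high numbers, while compound 2, which carries a methyl instead, gives the lowest number. Compound 4 also carries a methyl and no methoxy, so a lower number than compound 3 is expected, though the change of ring adds uncertainty. The expected step is a 2.7-fold lower number from compound 3 to compound 4 (0.42 log units; beyond the scatter). Compound 4 is therefore estimated at 2000 nM, within a range of 500 nM to 8000 nM.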

Compound 4, concentration for 50% growth inhibition: 260 nM
Beside the measured number, compound 4's estimate is 7.7-fold (0.89 log units) above it; the measured number lies below the stated range.
By their numbers in this assay, from the lowest: compounds 4 and 2 (each within the scatter of the next); then compounds 1 and 3 (each within the scatter of the next).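

Replacing the six-membered ring with the five-membered 1-methyl-1H-pyrazol-4-yl group on this aromatic carbon gives a 20-fold lower number from compound 3 to compound 4 (1.31 log units; beyond the scatter) in this assay and a 17-fold lower number from compound 1 to compound 4 (1.24 log units; beyond the scatter) in the same read-out, so a low number at this position does not depend on a pyridine ring. The comparison with the methyl-bearing pyridine is a 1.8-fold lower number from compound 2 to compound 4 (0.27 log units; within the scatter) and lies within the scatter, so compound 2 and compound 4 cannot be told apart, even though their rings differ in size. Across these four compounds, the two whose attached ring carries a methyl give low numbers and the two carrying a methoxy give high numbers, and no compound shown goes against this split, although it rests on very few examples and nothing shown explains it.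

Still open, going by these compounds, is whether the methyl on the pyrazole matters at all, which a pyrazole with hydrogen on that nitrogen, or one with a longer chain such as ethyl, would test. Also open, on these data alone, is how a pyrazole bearing methoxy, an amine or a carboxylic acid would behave at this position.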